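Nitro for hydrogen on two cores: cytotoxicity notes

A few compounds are considered here, and "the series" means these few. Any claim that something is new, unique, unknown or untested is made for them only; others in the source may bear on it.

Compound 1, `O=C(NN1Cc2ccccc2C1)c1ccccc1F`: 241000 nM.
Compound 2, `O=C(NN1Cc2ccccc2C1)c1cc([N+](=O)[O-])ccc1F`: > 331000 nM, which is a limit of the assay and not a number.
Compound 3, `O=C(NN(Cc1ccccc1)Cc1ccccc1)c1ccccc1Cl`: 50700 nM.

All values come from an ADME assay on L6 cells (Rattus norvegicus) for cytotoxicity; on this read-out higher numbers stand for weaker inhibition and lower numbers for stronger inhibition. The difference from compound 1 to compound 2 is nitro in place of hydrogen on an aromatic carbon; the step is an at least 1.3-fold higher number from compound 1 to compound 2 (0.13 log units; that floor lies within the scatter), and its size is a floor only because compound 2 sits at the limit of > 331000 nM in this assay, at which 1 of the 3 values shown sits. Compound 3 gives the lowest of the two numbers; how its core differs from the core of compound 1 is not broken down here. Compound 4, `O=C(NN(Cc1ccccc1)Cc1ccccc1)c1cc([N+](=O)[O-])ccc1Cl`, is not yet measured; it differs from compound 3 by nitro in place of hydrogen on an aromatic carbon, the same kind of change as from compound 1 to compound 2, though there the nitro sits para to a fluoro group and here para to a chloro group. For compound 4 a step of a 1.6-fold higher number from compound 3 to compound 4 (0.20 log units; within the scatter) is expected in this assay, resting on an at least 1.3-fold higher number from compound 1 to compound 2 (0.13 log units; that floor lies within the scatter). Compound 4 is thus estimated at 80000 nM, between 30000 nM and 250000 nM.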

Compound 4, half-maximal inhibitory concentration: 41700 nM
The estimate for compound 4 lay 1.9-fold (0.28 log units) above the measured number; low and high end bracket the measured number.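

In this assay, nitro in place of hydrogen on the core of compound 3 gives a 1.2-fold lower number from compound 3 to compound 4 (0.08 log units; within the scatter). Set beside the earlier step, the comparison across the two cores reads: the same change on two cores in this assay, an at least 1.3-fold higher number (0.13 log units; that floor lies within the scatter) from compound 1 to compound 2 and a 1.2-fold lower number (0.08 log units; within the scatter) from compound 3 to compound 4; the limit leaves it open whether they differ. The step on the core of compound 3 therefore shows no change beyond the scatter, but the pair of steps shows neither that the change carries over equally nor that it differs between the cores, and the earlier step ends in a limit of the assay, not a number: the limit of > 331000 nM in this assay, at which 1 of the 4 values shown sits.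

From the compounds shown here alone, whether an amine or a carboxylic acid in the place of the nitro would move the number beyond the scatter on either core remains open. Also open is what the fluoro and chloro groups contribute, as they change together with the core in the compounds shown.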